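The source may report more compounds than this note shows. Statements on the series, on what has been measured and on what is new or still open speak of the compounds shown alone.

Of the compounds shown here, three have so far been tested in a functional assay on the whole organism for inhibition, with Rattus norvegicus as the target, at a dose of 50 mg/kg by the oral route; a higher number here means a stronger effect of the compound at the dose given, a lower number a weaker effect. Compound 1 `Cn1c(-c2ccccc2)cc(=O)[nH]c1=O` gives 47%, and compound 3 `Cn1c(-c2ccccc2)c(I)c(=O)[nH]c1=O` gives 44%; the step of a number 3 percentage points lower from compound 1 to compound 3 (within the scatter) lies within the scatter. Compound 2 `Nc1nc(O)c(I)c(-c2ccccc2)n1`, which carries an amino group on its core, gives 3%, the lowest of the three numbers; compound 3 stands nearest to it and compound 1 furthest, and both gaps lie beyond the scatter.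

Compound 4 `Oc1nc(O)c(I)c(-c2ccccc2)n1` has not yet been measured. It differs from compound 2 in one place: hydroxy in place of amino on an aromatic carbon. Going by the values given here, none of the measured steps bears on this exchange; the only step recorded, from hydrogen to iodo, concerns a different group and was within the scatter, so it says nothing about swapping amino for hydroxy. In the absence of a comparable step, only a small change is expected, a number 7 percentage points higher from compound 2 to compound 4 (within the scatter). Compound 4 is therefore estimated at 10% in this assay, with an expected range from 0% to 35%.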

Compound 4, a percentage reported as inhibition, in the whole organism at one dose (the size of the read-out at that dose, not a potency): 41%
The estimate for compound 4 lay 31 percentage points below the measured number; the whole stated range lies below it.
By their numbers in this assay, from the lowest: compound 2; then compounds 4, 3 and 1 (each within the scatter of the next).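

In this assay, hydroxy in place of amino on the aromatic carbon between two ring nitrogen atoms gives a number 38 percentage points higher from compound 2 to compound 4 (beyond the scatter), so this position responds strongly to the group it carries. The two groups have the same counts of heavy atoms, hydrogen-bond donors and acceptors and the same net charge, so those counts alone do not separate a weak compound from a much stronger one, whereas the earlier exchange of hydrogen for iodo elsewhere on the core gave only a number 3 percentage points lower from compound 1 to compound 3 (within the scatter). Nothing available here explains the size of this step.

Going by these compounds, what a methoxy group, a methyl group or a plain hydrogen on this carbon would give remains open. Also open, on these data alone, is whether the same exchange would produce a similar step on a core without the iodo group.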